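Compound 3 to compound 4: a change on the aromatic nitrogen

A few compounds are considered here, and "the series" means these few. Any claim that something is new, unique, unknown or untested is made for them only; others in the source may bear on it.

Compounds measured in a functional assay on PC-3M cells (Homo sapiens) for antiproliferative activity, read by microscopy, with a stated time of 24 h (a higher number here means a weaker inhibitor, a lower number a stronger inhibitor), so far
- Compound 1 `Cc1c(C)n(Cc2ccccc2)c2ncn(C3CCOCC3)c(=N)c12` gives > 20000 nM (a limit of the assay)
- Compound 2 `COc1ccc(Cn2c(-c3ccccc3)c(-c3ccccc3)c3c(=N)n(CCCO)cnc32)cc1` gives 2170 nM; 2140 nM (2 entries)
- Compound 3 `COc1ccc(-c2c(-c3ccc(OC)cc3)n(Cc3ccccc3)c3ncn([C@H]4CC[C@H](O)CC4)c(=N)c23)cc1` gives > 20000 nM (a limit of the assay)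

For compound 3 the entry > 20000 nM is a limit and not a number. Two of the three values sit at this limit (the limit of > 20000 nM in this assay, at which 2 of the 3 values shown sit). Only compound 2 gives numbers, and its repeat entries agree (the several entries of compound 2 in this assay, 2170 nM; 2140 nM (2 entries)).

The next step leads to compound 4 `COc1ccc(-c2c(-c3ccc(OC)cc3)n(Cc3ccccc3)c3ncn(C4CCOCC4)c(=N)c23)cc1` and places oxan-4-yl in place of 4-hydroxycyclohexyl on an aromatic nitrogen. Among the measured compounds shown here, no pair of measured compounds differs in one place, so the size of this step cannot be read from the data. No step beyond the scatter is expected in this assay, and a reported limit is as likely as a number. This expectation rests on compound 1, which also carries oxan-4-yl and whose entry > 20000 nM is a limit of the assay. The expected step is an at least 1.3-fold lower number from compound 3 to compound 4 (0.12 log units; that floor lies within the scatter) and is no more than an estimate set against a limit. The estimate for compound 4 is 15000 nM with 6000 nM to 20000 nM as its expected range.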

Compound 4, half-maximal inhibitory concentration: > 20000 nM
Compound 4: only a limit was reported; the forecaster's own chance of this, stated with the estimate: 60%; middle value at least 1.3-fold (0.12 log units) from the limit.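

The step between compound 3 and compound 4 in this assay cannot be read, since both entries are limits of the assay and not numbers: the limit of > 20000 nM in this assay, at which 3 of the 4 values shown sit.

The compounds shown leave open whether oxan-4-yl in place of 4-hydroxycyclohexyl on an aromatic nitrogen changes the read-out at all on this shared core, as no pair with numbers on both sides carries that change.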